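The source may hold more compounds than are shown below. What is called first, only, known or untested is meant among the compounds shown, and "the series" means these compounds.

Working notes on the series, step from compound 3 to compound 4.

The shared core carries two 4-methoxyphenyl groups; the compounds differ only in the group on the remaining aromatic carbon. Compound 1 `COc1ccc(-c2nc(/N=C(\N)NC(C)C)sc2-c2ccc(OC)cc2)cc1` carries a guanidine-type group with an isopropyl chain, and in a functional assay with Oryctolagus cuniculus as the target (a lower number here means a stronger inhibitor, a higher number a weaker inhibitor), compound 1 gives only a limit, > 100 nM. Compound 2 `COc1ccc(-c2nc(/N=C(\N)[N+]3(C)CCCCC3)sc2-c2ccc(OC)cc2)cc1` carries the ring-bearing analogue of that group, and in this assay compound 2 gives only a limit, > 1000 nM. Compound 3 `COc1ccc(-c2nc(C(N)=O)sc2-c2ccc(OC)cc2)cc1` carries the carbamoyl group, and in this assay compound 3 likewise gives only a limit, > 1000 nM. Compound 3 thus stands at the weaker limit, together with compound 2 (the limit of > 1000 nM in this assay, at which 2 of the 3 values shown sit), while compound 1 sits at the other limit (the limit of > 100 nM in this assay, at which 1 of the 3 values shown sits). Within the data shown here, none of the measured steps can be read: a step that the two limits leave unreadable from compound 1 to compound 2, a step that the two limits leave unreadable from compound 1 to compound 3 and a step that the two limits leave unreadable from compound 2 to compound 3 are all left open by the limits.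

Compound 4 `COc1ccc(-c2nc(C3=CCN(C)CC3)sc2-c2ccc(OC)cc2)cc1` differs from compound 3 as follows: a group of 7 heavy atoms (6 carbon, 1 nitrogen; one six-membered non-aromatic ring with 1 hetero atom) in place of a group of 3 heavy atoms (1 carbon, 1 nitrogen, 1 oxygen; no ring), on an aromatic carbon. Among the measured compounds shown here, no measured step bears on this change, since no step has a readable size; all three measured values point to weak inhibition. For compound 4 a step that the limit leaves unreadable from compound 3 to compound 4 is expected, that is, no change beyond the scatter, and compound 4 is estimated at 2000 nM with a range from 300 nM to 20000 nM.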

Compound 4, half-maximal inhibitory concentration: < 10 nM
Compound 4 was reported as a limit (the forecaster's own chance of this, stated with the estimate: 65%); at least 200-fold (2.30 log units) between middle value and limit.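

In this assay, among these compounds, compound 4 gives < 10 nM, which is a limit of the assay and the only value at this end of the series: the limit of < 10 nM in this assay, at which 1 of the 4 values shown sits. This position, the aromatic carbon of the five-membered aromatic ring next to the ring nitrogen and next to the ring sulfur, proves sensitive to the group it carries, with an at least 100-fold lower number from compound 3 to compound 4 (2.00 log units; beyond the scatter), an at least 100-fold lower number from compound 2 to compound 4 (2.00 log units; beyond the scatter) and an at least 10-fold lower number from compound 1 to compound 4 (1.00 log units; beyond the scatter), whereas the steps among the three earlier compounds cannot be read. A six-membered non-aromatic ring with 1 hetero atom does not by itself go with the low number, since compound 2 also carries such a ring and stays at the weak end.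

Going by these compounds, all three steps rest on limits at both ends, so their true sizes remain open, and compound 4 cannot be placed any more closely. The compounds shown also do not tell whether the same result would follow from a fully saturated piperidine ring, a phenyl ring or an open-chain amine at this carbon, so the part of the entering group that matters remains unresolved.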